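The compounds below may be only part of what the source reports. "The series", "measured", "known", "first", "only" and "open" are said of these compounds alone.

Measured compounds:
compound 1, `C=CC(=O)Nc1cccc(Nc2ncnc(Nc3ccc(-c4cccnc4)cc3)n2)c1`: > 100000 nM
compound 2, `C=CC(=O)Nc1cccc(Nc2ncnc(Nc3ccc(C(=O)Nc4ccccn4)cc3)n2)c1`: "not determined" (no result reported)
compound 3, `C=CC(=O)Nc1cccc(Nc2ncnc(Nc3ccc(-c4ccc(F)nc4)cc3)n2)c1`: 59200 nM
compound 4, `C=CC(=O)Nc1cccc(Nc2ncnc(Nc3ccc(OCCOC)cc3)n2)c1`: not yet measured

The three measured compounds share one core and differ only at the far end of the anilino arm. In a functional assay on Ramos cells (Homo sapiens) for antiproliferative activity, read by CCK-8 assay, with a stated time of 24 h (on this read-out lower numbers stand for stronger inhibition and higher numbers for weaker inhibition), compound 1 gives > 100000 nM, which is a limit of the assay and not a number (the limit of > 100000 nM in this assay, at which 1 of the 3 values shown sits). For compound 2 the result is "not determined" (no result reported). Compound 3 gives 59200 nM. Within the data shown here, the one measured step is an at least 1.6-fold lower number from compound 1 to compound 3 (0.22 log units; that floor lies within the scatter), a fluoro in place of hydrogen on an aromatic carbon; its floor lies within the scatter, so it shows no change that can be relied upon.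

Compound 4 differs from compound 1 in one place: 2-methoxyethoxy in place of pyridin-3-yl on an aromatic carbon. Among the measured compounds shown here, no measured step bears on this exchange of a ring for a chain, so the only guide is that compound 1 itself sits at the limit. Compound 4 is therefore expected to remain weak, with an estimated 100000 nM in a range from 30000 nM to 300000 nM. The estimate for compound 4 means an expected a number no higher from compound 1 to compound 4 (the limit leaves the size open), with a real chance that again only a limit is reported.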

Compound 4, half-maximal inhibitory concentration: 181000 nM
Compound 4: the middle estimate sits 1.8-fold (0.26 log units) below what was measured, and the stated range covers the measured number.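

In this assay, among these compounds, 2-methoxyethoxy in place of 6-fluoropyridin-3-yl gives a 3.1-fold higher number from compound 3 to compound 4 (0.49 log units; beyond the scatter) and so provides the first step at this position that lies beyond the scatter. The group on this aromatic carbon can therefore shift the number, and here the open chain reads higher than the fluorinated ring. The step from compound 1 to compound 4 cannot be read, because compound 1 stands at a limit and not at a number: the limit of > 100000 nM in this assay, at which 1 of the 4 values shown sits.

Since compound 3 carries a fluoro on its ring, the compounds shown do not separate the effect of that fluoro from the effect of losing the ring. They also leave open how an amine or a carboxylic acid, or a longer chain than 2-methoxyethoxy, would read at this position.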